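Isopropyl in Place of Methyl on the Aryl Ether Oxygen

The source may report more compounds than this note shows. Statements on the series, on what has been measured and on what is new or still open speak of the compounds shown alone.

Compound 1 `COc1cncc(C2=CC3CC(C2)CN(C)C3)c1` was tested in an in vitro functional assay on SH-EP1 cells for agonist activity at Neuronal acetylcholine receptor; alpha4/beta2 (Homo sapiens), read by FLIPR and calcium flux (a lower number here means that less compound is needed, a higher number that more compound is needed for the effect), and gave 2660 nM. For the measured compounds named here, of the two numbers recorded in this assay, that of compound 1 is the higher, and the gap to its only companion lies beyond the scatter: compound 2 `C1=C(c2cncc(Oc3ccccc3)c2)CC2CNCC1C2` gave 62 nM in this assay, though it differs from compound 1 in more than one place, so no single step separates the two. Compound 3 `CC(C)Oc1cncc(C2=CC3CC(C2)CN(C)C3)c1` keeps the core of compound 1 and differs from it only at the ether: isopropyl in place of methyl on an oxygen on an aromatic ring. Going by the values given here, no measured pair shows what this change does, so the expectation rests on compound 1 alone. The step from compound 1 to compound 3 is expected to be small and towards a lower number, a 1.8-fold lower number from compound 1 to compound 3 (0.25 log units; within the scatter), not clearly beyond the scatter. For compound 3 in this assay the estimate is 1500 nM, with a range from 400 nM to 5000 nM.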

Compound 3, half-maximal effective concentration: > 10000 nM
Compound 3: only a limit was reported (the forecaster's own chance of this, stated with the estimate: 5%); middle value at least 6.6-fold (0.82 log units) away from the limit.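

For the compounds shown here, on the shared core, this is the first step measured in a single place, and it runs towards a higher number: methoxy to isopropoxy on the aromatic ring gives an at least 3.7-fold higher number from compound 1 to compound 3 (0.57 log units; beyond the scatter) in this assay. The oxygen substituent therefore affects the read-out here, and going from methyl to isopropyl on this core means that more compound is needed, with a gap that is beyond the scatter. The reading for compound 3 is a limit and not a number: the limit of > 10000 nM in this assay, at which 1 of the 3 values shown sits.

Going by these compounds, how far the number climbs therefore stays unknown, as does whether ethyl on the same oxygen would already shift it. On these data alone, compound 2 differs from compound 1 and compound 3 in more than one place, so what a phenyl on this oxygen contributes also remains open.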